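This account rests on a few compounds, and the source may have more. Where it says the series, first, only, none or still open, it means among the compounds named here.

Measured compounds:
compound 1, `CCOC(=O)c1c(N)sc(/N=C/c2ccc(N(C)C)cc2)c1C(=O)OCC`: 73000 nM
compound 2, `CCOC(=O)c1c(N)sc(/N=C/c2ccncc2)c1C(=O)OCC`: 119000 nM
compound 3, `CCOC(=O)c1c(N)sc(/N=C/c2ccc(C)cc2)c1C(=O)OCC`: 52500 nM

All three share the same core and differ only in the group on the carbon with a double bond to nitrogen. In a functional assay on Ishikawa cells (Homo sapiens) for inhibition, read by MTT assay, with a stated time of 48 h (on this read-out lower numbers stand for stronger inhibition and higher numbers for weaker inhibition), compound 1 gives 73000 nM, the second highest of the three numbers. Its nearest neighbour is compound 3 with 52500 nM, and a 1.4-fold lower number from compound 1 to compound 3 (0.14 log units; within the scatter). The furthest is compound 2 with 119000 nM, and a 1.6-fold higher number from compound 1 to compound 2 (0.21 log units; within the scatter). Going by the values given here, the only step that reaches beyond the scatter is a 2.3-fold lower number from compound 2 to compound 3 (0.36 log units; beyond the scatter), and even that one is modest; the spread across the three is narrow.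

Compound 4, `CCOC(=O)c1c(N)sc(/N=C/c2ccc(F)cc2)c1C(=O)OCC`, is not yet measured. It differs from compound 1 by fluoro in place of dimethylamino on an aromatic carbon. The step that bears most directly on it is the exchange of the same dimethylamino group for methyl, a 1.4-fold lower number from compound 1 to compound 3 (0.14 log units; within the scatter), which stayed within the scatter; the exchange of the whole 4-(dimethylamino)phenyl for pyridin-4-yl, a 1.6-fold higher number from compound 1 to compound 2 (0.21 log units; within the scatter), also stayed within the scatter. Nothing seen so far suggests that a change at this position moves this assay by more than the scatter. For compound 4 the expected step is therefore a 1.2-fold lower number from compound 1 to compound 4 (0.07 log units; within the scatter), within the scatter. Compound 4 is estimated at 62000 nM, with a range of 30000 nM to 125000 nM.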

Compound 4, half-maximal inhibitory concentration: 32100 nM
Compound 4: middle estimate off by 1.9-fold (0.29 log units), on the high side, within the range that was stated.
By their numbers in this assay, from the lowest: compounds 4, 3, 1 and 2 (each within the scatter of the next, the first and the last beyond it).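

In this assay, going by these compounds alone, the exchange of dimethylamino for fluoro on the aromatic carbon is the first change from compound 1 at this position to pass the scatter (a 2.3-fold lower number from compound 1 to compound 4 (0.36 log units; beyond the scatter)), whereas the exchange of dimethylamino for methyl stayed within it. Fluoro and methyl themselves are not separated (a 1.6-fold lower number from compound 3 to compound 4 (0.21 log units; within the scatter)), so the 4-fluorophenyl group stands apart from 4-(dimethylamino)phenyl without standing apart from 4-methylphenyl, and the widest gap in the set now lies against pyridin-4-yl (a 3.7-fold lower number from compound 2 to compound 4 (0.57 log units; beyond the scatter)). No measurement at hand offers an explanation for these differences, so they remain a description of four compounds.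

The compounds shown leave open whether the step belongs to fluoro in particular or would also appear with another small group at the same place, such as chloro, methoxy or a nitrile. They also leave open how far the numbers would move with a change elsewhere on the shared core, such as a carboxylic acid or an amide in place of an ethyl ester.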